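Series notes: aryl-amide quinolones and liver microsome clearance

The source may hold more compounds than are shown below. What is called first, only, known or untested is meant among the compounds shown, and "the series" means these compounds.

Measured so far in an ADME assay on microsomes from liver (Rattus norvegicus) for metabolic stability, with a stated time of 30 min; on this read-out lower numbers stand for slow clearance and higher numbers for fast clearance:
- compound 1, `Cn1cc(C(=O)Nc2ccc(-c3ccccc3)c(C(F)(F)F)c2)c(=O)c2ncccc21`, gives < 14 uL/min, which is a limit of the assay rather than a number.
- compound 2, `Cn1cc(C(=O)Nc2ccc(-c3ccccc3)c(C(F)(F)F)c2)c(=O)c2ccccc21`, gives < 14 uL/min, again a limit of the assay.
- compound 3, `Cn1cc(C(=O)Nc2ccc(-c3ccccc3)c(C(F)(F)F)c2)c(=O)c2cccnc21`, gives < 14 uL/min, also a limit of the assay.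

Compound 2 therefore stands at the floor of the read-out: its value is a limit, not a number, and the same holds for the two other values shown, so that the limit of < 14 uL/min in this assay, at which 3 of the 3 values shown sit, describes the whole set. No pair among these three compounds differs in one place, so no measured step is available, and nothing can be said about order among them.

The next compound, compound 4, `Cn1cc(C(=O)Nc2ccc(-c3ccccn3)c(C(F)(F)F)c2)c(=O)c2ccccc21`, differs from compound 2 in one place: pyridin-2-yl in place of phenyl on an aromatic carbon.

Within the data shown here, with every value sitting at the limit, there is no measured step on which to base a direction for this change. The expectation for the step from compound 2 to compound 4 in this assay is a step that the limit leaves unreadable from compound 2 to compound 4, that is, nothing beyond the usual scatter. For compound 4 the estimated value in this assay is 10 uL/min, with a range from 5 uL/min to 25 uL/min, and it is expected that the assay will most likely again report only a limit.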

Compound 4, intrinsic clearance in a liver preparation (reported as CLH), per the amount of preparation that the assay uses in the Rattus norvegicus assay: < 14 uL/min
Compound 4: only a limit was reported; the forecaster's own chance of this, stated with the estimate: 70%; the middle value does not contradict the limit.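

In the Rattus norvegicus assay compound 2 and compound 4 each return only a limit, so no step can be read between them. In a physicochemical assay for solubility, at pH 7.4 (a lower number here means a less soluble compound, a higher number a more soluble compound), compound 2 gives 1.3 ug/mL and compound 4 gives 12 ug/mL, which is a 9.2-fold higher number from compound 2 to compound 4 (0.97 log units; beyond the scatter). As far as these compounds go, whether pyridin-2-yl in place of phenyl alters clearance stays open, as every clearance result is a limit: the limit of < 14 uL/min in the Rattus norvegicus assay, at which 4 of the 4 values shown sit.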